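Swapping a piperidine for a bromophenyl on the amine side chain

A few compounds are considered here, and "the series" means these few. Any claim that something is new, unique, unknown or untested is made for them only; others in the source may bear on it.

Measured compounds:
- compound 1, `O=C(O)c1cccc(CNc2cc(C(F)(F)F)cc3[nH]ncc23)c1`: 94%
- compound 2, `OC1CCCC(Nc2cccc(CNc3cc(C(F)(F)F)cc4[nH]ncc34)c2)C1`: 23%
- compound 3, `FC(F)(F)c1cc(NC[C@@H]2CCCCN2)c2cn[nH]c2c1`: 88%

Of the compounds shown here, three sharing one core have been tested in an assay for inhibition of Tryptophan 2,3-dioxygenase (Homo sapiens), with stated times of 10 min and 60 min, tested at 100 uM; a higher number here means a stronger effect of the compound at the concentration tested, a lower number a weaker effect. Compound 1 and compound 3 sit close together at the top, and their gap is within the scatter, so neither can be called stronger than the other. Compound 2 lies far below both. Within the data shown here, the only step recorded between compounds that differ in one place is a number 71 percentage points lower from compound 1 to compound 2 (beyond the scatter), so a change on the aromatic ring attached to the chain carbon can cost much of the effect.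

Compound 4, `FC(F)(F)c1cc(NCc2cccc(Br)c2)c2cn[nH]c2c1`, has not yet been measured in this assay. It differs from compound 3 by 3-bromophenyl in place of piperidin-2-yl on a saturated chain carbon bound to a nitrogen on an aromatic ring.

Among the measured compounds shown here, no measured step covers this exact change. Compound 1 shows that an aromatic ring at this chain position is compatible with high inhibition, while compound 2 shows that the substitution on that ring matters a great deal. With only that to go on, compound 4 is expected to keep a substantial effect, with a step estimated as a number 18 percentage points lower from compound 3 to compound 4 (beyond the scatter). The estimate for compound 4 in this assay is 70%, with a range from 30% to 95%.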

Compound 4, a percentage reported as inhibition, at one concentration (the size of the read-out at that concentration, not a potency): 84%
For compound 4 the middle estimate is 14 percentage points below the measured one; measured number inside the range.
By their numbers in this assay, from the lowest: compound 2; then compounds 4, 3 and 1 (each within the scatter of the next).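

In this assay, 3-bromophenyl in place of piperidin-2-yl on a saturated chain carbon bound to a nitrogen on an aromatic ring gives a number 4 percentage points lower from compound 3 to compound 4 (within the scatter), so at this single test concentration the position tolerates both a non-aromatic ring with a hydrogen-bond donor and acceptor and a carbon-only aromatic ring with neither. Bromo in place of carboxy on an aromatic carbon gives a number 10 percentage points lower from compound 1 to compound 4 (within the scatter), which shows that the carboxy group is not needed for a high reading on this aromatic ring. Bromo in place of (3-hydroxycyclohexyl)amino gives a number 61 percentage points higher from compound 2 to compound 4 (beyond the scatter), so among the compounds with an aromatic ring at this position, only compound 2 reads low, and the large loss is tied to that one substituent rather than to the aromatic ring itself.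

No measurement shown here offers a reason for any of these results. As far as these compounds go, it remains open whether an unsubstituted phenyl, or a ring with a methoxy or an aminomethyl group in place of the bromo, would keep this level of inhibition, and whether a longer chain between the nitrogen and the ring would do so.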